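Swapping vinyl for 4-bromophenyl on the sulfur-bound chain carbon

The source may report more compounds than this note shows. Statements on the series, on what has been measured and on what is new or still open speak of the compounds shown alone.

- compound 1 `Cc1cc(N2CC[C@@H](C)[C@@H](N(C)c3ncnc4[nH]ccc34)C2)n2nc(SCc3ccccc3)nc2n1`: 14400 nM
- compound 2 `C=CCSc1nc2nc(C)cc(N3CC[C@@H](C)[C@@H](N(C)c4ncnc5[nH]ccc45)C3)n2n1`: 40900 nM

In a functional assay on BGC-823 cells (Homo sapiens) for inhibition, read by MTT assay, with a stated time of 72 h (a lower number here means a stronger inhibitor, a higher number a weaker inhibitor), compound 2 gives the higher of the two numbers at 40900 nM, and compound 1 lies nearest at 14400 nM. The next compound, compound 3 `Cc1cc(N2CC[C@@H](C)[C@@H](N(C)c3ncnc4[nH]ccc34)C2)n2nc(SCc3ccc(Br)cc3)nc2n1`, has 4-bromophenyl in place of vinyl on a saturated chain carbon bound to a sulfur. Going by the values given here, the only measured step bearing on this change is a 2.8-fold higher number from compound 1 to compound 2 (0.45 log units; beyond the scatter), which is modest but beyond the scatter. It is the vinyl-for-phenyl exchange at the same place, so read in reverse it points to a lower number. Among the compounds with values here, no measurement yet covers the bromine. In this assay the expected change is a 3.1-fold lower number from compound 2 to compound 3 (0.50 log units; beyond the scatter), of similar size to the measured step. For compound 3 the estimated value is 13000 nM, with an expected range of 5000 nM to 32000 nM.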

Compound 3, half-maximal inhibitory concentration: 28000 nM
Estimate against measurement, compound 3: 2.2-fold (0.33 log units) below, and the stated range covers the measured number.
By their numbers in this assay, from the lowest: compounds 1, 3 and 2 (each within the scatter of the next, the first and the last beyond it).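

In this assay, 4-bromophenyl in place of vinyl on a saturated chain carbon bound to a sulfur gives a 1.5-fold lower number from compound 2 to compound 3 (0.16 log units; within the scatter) and bromo in place of hydrogen on an aromatic carbon gives a 1.9-fold higher number from compound 1 to compound 3 (0.29 log units; within the scatter) and both steps lie within the scatter. Compound 3 therefore cannot be separated from either neighbour, and only compound 1 and compound 2 remain apart, so allyl, benzyl and 4-bromobenzyl at this position span a narrow range of numbers. No available evidence accounts for these numbers.

As far as these compounds go, whether a carboxylic acid or an amine on the phenyl, or a longer chain on the sulfur, would take the number outside this range remains open. Also open, from the compounds shown here alone, is how the series would respond to an amine in place of the sulfur.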